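Series Notes: Aryl Variation at the Saturated Ring Carbon

A few compounds are considered here, and "the series" means these few. Any claim that something is new, unique, unknown or untested is made for them only; others in the source may bear on it.

Three compounds share one core. Compound 1 `Cc1ccc(C2C(C#N)=C(N)N(c3ccc(S(N)(=O)=O)cc3)C3=C2C(=O)CCC3)cc1` gives 30% in a functional assay on Ehrlich cells (Mus musculus) for antiproliferative activity, read by trypan blue exclusion, with a stated time of 2 h, tested at 25 ug/mL; a lower number here means a weaker effect, a higher number a stronger effect of the compound at the concentration tested. Compound 2 `COc1ccccc1C1C(C#N)=C(N)N(c2ccc(S(N)(=O)=O)cc2)C2=C1C(=O)CCC2` gives 0% and compound 3 `COc1cc(CC2C(C#N)=C(N)N(c3ccc(S(N)(=O)=O)cc3)C3=C2C(=O)CCC3)ccc1O` gives 50%, so compound 2 stands lowest of the three. Compound 4 `N#CC1=C(N)N(c2ccc(S(N)(=O)=O)cc2)C2=C(C(=O)CCC2)C1c1ccc(Cl)cc1Cl` is not yet measured; it differs from compound 2 as 2,4-dichlorophenyl in place of 2-methoxyphenyl on a saturated ring carbon. Within the data shown here, the steps that bear on it both start from compound 2: a number 30 percentage points lower from compound 1 to compound 2 (beyond the scatter) and a number 50 percentage points higher from compound 2 to compound 3 (beyond the scatter). Every change away from the 2-methoxyphenyl group has moved the read-out upward, the aryl-to-aryl step modestly, the aryl-to-benzyl step largely. Since compound 4 keeps an aryl group, the expectation is a modest upward step, a number 20 percentage points higher from compound 2 to compound 4 (beyond the scatter). Compound 4 is therefore estimated at 20%, within 0% to 45%.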

Compound 4, a percentage reported as activity, at one concentration (the size of the read-out at that concentration, not a potency): 50%
Compound 4: the middle estimate sits 30 percentage points below what was measured; the whole stated range lies below it.
By their numbers in this assay, from the lowest: compound 2; then compound 1; then compounds 3 and 4 (each within the scatter of the next).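

In this assay the 2,4-dichlorophenyl group gives a number 50 percentage points higher from compound 2 to compound 4 (beyond the scatter) and a number 20 percentage points higher from compound 1 to compound 4 (beyond the scatter) at this saturated ring carbon, so the large upward step from the 2-methoxyphenyl group is no longer confined to the 4-hydroxy-3-methoxybenzyl group. With no change at the digits printed from compound 3 to compound 4 (within the scatter) as well, an aryl group and a benzyl group stand level here, and the aryl groups shown span the whole range of the series. No measurement on hand accounts for these differences. The compounds shown leave open whether both chlorines are needed, since neither single-chlorine phenyl group appears. They also leave open how an aminophenyl group or a carboxylic acid on the phenyl ring would read at this carbon.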